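This account rests on a few compounds, and the source may have more. Where it says the series, first, only, none or still open, it means among the compounds named here.

Measured so far:
- compound 1 `O=C1NC(=O)/C(=C/c2ccc(OCCSc3nnc(Cc4ccccc4)[nH]3)cc2)S1`: 18.3%
- compound 2 `O=C1NC(=O)/C(=C/c2ccc(OCCSc3nnc(-c4ccccc4[N+](=O)[O-])[nH]3)cc2)S1`: 14.6%

Both compounds were tested in a functional assay on the whole organism (plasma, strain Wistar) with Rattus norvegicus as the target, with a stated time of 15 days, at a dose of 3 mg/kg by the oral route (on this read-out higher numbers stand for a stronger effect at the one dose given and lower numbers for a weaker effect), where compound 1 gives 18.3% and compound 2 gives 14.6%. Only these two numbers exist, so compound 2 can be placed only against compound 1: the step of a number 3.7 percentage points lower from compound 1 to compound 2 (within the scatter) lies within the scatter, and the two compounds cannot be told apart on this read-out.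

Compound 3 `O=C1NC(=O)/C(=C/c2ccc(OCCSc3nnc(-c4ccc(Br)cc4)[nH]3)cc2)S1` has not yet been measured. Compared with compound 2, it differs in one place: 4-bromophenyl in place of 2-nitrophenyl on an aromatic carbon.

For the measured compounds named here, the one measured step that bears on this change is the exchange of one group on the same aromatic carbon of the shared core, from compound 1 to compound 2, and it stayed within the scatter. Going by the values given here, no measured compound carries a bromine, so nothing shows how a 4-bromophenyl group in that place behaves. The expectation is therefore a step of no size beyond the scatter, a number 1.4 percentage points higher from compound 2 to compound 3 (within the scatter). Compound 3 is expected to give about 16% in this assay, with a likely range from 7% to 27%.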

Compound 3, a percentage reported as activity, at one dose (the size of the read-out at that dose, not a potency): 13.2%
For compound 3 the middle estimate is 2.8 percentage points above the measured one, and the stated range covers the measured number.
By their numbers in this assay, from the lowest: compounds 3, 2 and 1 (each within the scatter of the next).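

Putting 4-bromophenyl in place of 2-nitrophenyl on the aromatic carbon of the five-membered aromatic ring with 3 nitrogen gives only a small step in this assay (a number 1.4 percentage points lower from compound 2 to compound 3 (within the scatter)), and putting it in place of benzyl gives another (a number 5.1 percentage points lower from compound 1 to compound 3 (within the scatter)). Benzyl, 2-nitrophenyl and 4-bromophenyl therefore cannot be told apart on this read-out, even though 2-nitrophenyl counts 2 hydrogen-bond acceptors and 4-bromophenyl counts 0, and a bromine now stands in this place for the first time. Nothing measured here says why these three groups give such similar numbers.

From the compounds shown here alone, all three groups carry a six-membered aromatic ring of carbon only, so it remains open whether a methyl group, a carboxylic acid or an amine in this place, or a longer chain in place of benzyl, would give a number beyond the scatter. Each compound is also seen at a single dose, which leaves open whether these compounds would still be indistinguishable at other doses.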